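Carboxymethyl on the Phenolic Oxygen: a Cytotoxicity Step

This account rests on a few compounds, and the source may have more. Where it says the series, first, only, none or still open, it means among the compounds named here.

Compound 1, `COc1ccc(-c2nc3ccccc3s2)cc1NC(=O)c1cc([N+](=O)[O-])ccc1Cl`: in an ADME assay on BJ cells (Homo sapiens) for cytotoxicity, with a stated time of 72 h (a lower number here means that less compound is needed, a higher number that more compound is needed for the effect), compound 1 gives > 25000 nM, which is a limit of the assay rather than a number.
Compound 2, `O=C(Nc1cccc(-c2nc3ccccc3s2)c1)c1cc([N+](=O)[O-])c(O)cc1Cl`: in this assay compound 2 gives > 25000 nM, again a limit of the assay and not a number.

Compound 2 therefore stands at the edge of what this assay can report, and compound 1 stands there with it; the two values shown give no order between them. Among the compounds with values here, the single piece of evidence on the measured values is the limit of > 25000 nM in this assay, at which 2 of the 2 values shown sit, so no step between measured compounds is available to calibrate the next change.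

The untested compound is compound 3, `O=C(O)COc1cc(Cl)c(C(=O)Nc2cccc(-c3nc4ccccc4s3)c2)cc1[N+](=O)[O-]`. It differs from compound 2 in one place: carboxymethyl in place of hydrogen on an oxygen on an aromatic ring. With both measured values sitting at the limit, there is no basis for expecting the step in this assay to move compound 3 in either direction beyond the usual scatter. The expectation is that compound 3 again reaches only the limit, so the estimated value for compound 3 is 30000 nM, with a range from 10000 nM to 100000 nM, and the estimated step that the limit leaves unreadable from compound 2 to compound 3 is none beyond the scatter.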

Compound 3, half-maximal effective concentration: > 25000 nM
Compound 3: a limit, no number; the forecaster's own chance of this, stated with the estimate: 80%; the middle value lies beyond the limit too.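

In this assay compound 3 gives > 25000 nM, which is a limit of the assay and not a number. Compound 2 also sits at a limit, so no step can be read from compound 2 to compound 3: the limit of > 25000 nM in this assay, at which 3 of the 3 values shown sit.

The compounds shown leave open whether any of them has a measurable effect on these cells, and how carboxymethyl in place of hydrogen would act in a compound that gives a number.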